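This account rests on a few compounds, and the source may have more. Where it says the series, first, only, none or still open, it means among the compounds named here.

Measured in an ADME assay on microsomes from liver (Homo sapiens) for metabolic stability, read by LC-MS, using NADPH, with a stated time of 10 min, tested at 10 uM; on this read-out lower numbers stand for a shorter-lived compound and higher numbers for a longer-lived compound:
compound 1 `Nc1ncnc2c1c(Oc1cc(C(F)(F)F)ccn1)nn2[C@H]1CC[C@@H](CO)CC1` gives 1.6 h
compound 2 `Nc1ncnc2c1c(Oc1cc(O)ccn1)nn2C1CCC(F)(F)CC1` gives > 2.41 h
compound 3 `CC(C)(C)n1nc(Oc2cc(O)ccn2)c2c(N)ncnc21` gives 1.4 h

The value of compound 2 is a limit of this assay and not a number (the limit of > 2.41 h in this assay, at which 1 of the 3 values shown sits). Compound 1 and compound 3 sit within the scatter of one another, so no order between them is claimed. Among the compounds with values here, the only measured step at the aromatic nitrogen is an at least 1.7-fold lower number from compound 2 to compound 3 (0.23 log units; that floor lies within the scatter), whose floor lies within the scatter. Compound 4 `Nc1ncnc2c1c(Oc1cc(C(F)(F)F)ccn1)nn2C1CCC1` remains to be measured; it differs from compound 1 by cyclobutyl in place of 4-(hydroxymethyl)cyclohexyl on an aromatic nitrogen. Within the data shown here, only the step from compound 2 to compound 3 bears on this change, and it gives no clear direction. For compound 4 the expected step is a 1.2-fold lower number from compound 1 to compound 4 (0.09 log units; within the scatter), nothing beyond the scatter. Compound 4 is estimated at 1.3 h, between 0.6 h and 2.4 h.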

Compound 4, half-life: 1.02 h
Estimate against measurement, compound 4: 1.3-fold (0.11 log units) above; the measured number falls inside the stated range.
By their numbers in this assay, from the lowest: compounds 4, 3 and 1 (each within the scatter of the next). At a limit, above all of these: compound 2.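

In this assay, cyclobutyl in place of 4-(hydroxymethyl)cyclohexyl on the aromatic nitrogen gives a 1.6-fold lower number from compound 1 to compound 4 (0.20 log units; within the scatter), so the larger ring and its hydroxymethyl can both go without a change beyond the scatter. Unlike the step from compound 2 to compound 3, this step rests on two numbers and not on a limit. Nothing shown gives a cause for this step.

The contributions of ring size and the hydroxymethyl remain unseparated. Also open, on these data alone, is whether an amine or a carboxylic acid at this position would move the half-life beyond the scatter.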